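A few compounds are considered here, and "the series" means these few. Any claim that something is new, unique, unknown or untested is made for them only; others in the source may bear on it.

Measured so far in a functional assay on U-937 cells (Homo sapiens) for cytotoxicity, read by MTT assay, with a stated time of 48 h; on this read-out lower numbers stand for stronger inhibition and higher numbers for weaker inhibition:

compound 1, `Fc1cccc(-c2nc(Nc3ccc(Cl)cc3)c3cc(F)ccc3n2)c1`, 32700 nM
compound 2, `Fc1cccc(-c2nc(Nc3ccccc3Cl)c3cc(F)ccc3n2)c1`, reported only as a limit, > 50000 nM
compound 3, `Fc1cccc(-c2nc(Nc3cccc(Br)c3)c3cc(F)ccc3n2)c1`, reported only as a limit, > 50000 nM

Going by the values given here, compound 1 carries the only number; the other two values are limits, and the limit of > 50000 nM in this assay, at which 2 of the 3 values shown sit, marks where they sit. Moving the halogen on the phenyl gives an at least 1.5-fold higher number from compound 1 to compound 2 (0.18 log units; that floor lies within the scatter), with 2-chlorophenyl in place of 4-chlorophenyl on a nitrogen on an aromatic ring, and an at least 1.5-fold higher number from compound 1 to compound 3 (0.18 log units; that floor lies within the scatter), with 3-bromophenyl in place of 4-chlorophenyl on the same nitrogen. Between the two limits the comparison is a step that the two limits leave unreadable from compound 2 to compound 3.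

Compound 4, `Nc1ccccc1Nc1nc(-c2cccc(F)c2)nc2ccc(F)cc12`, changes the same phenyl: 2-aminophenyl in place of 4-chlorophenyl on a nitrogen on an aromatic ring. Both measured steps bear on it, since each also replaces the 4-chlorophenyl on that nitrogen and each reaches only the limit; neither gives a readable size. The expectation for compound 4 is therefore a step toward weaker inhibition of about a 1.5-fold higher number from compound 1 to compound 4 (0.17 log units; within the scatter), with a real chance that this assay again returns only a limit. Compound 4 is estimated at 48000 nM, in a range from 15000 nM to 150000 nM.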

Compound 4, half-maximal inhibitory concentration: 47300 nM
Compound 4: the middle estimate sits 1.0-fold (0.01 log units) above what was measured; measured number inside the range.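

In this assay, the 2-aminophenyl on this nitrogen yields a second readable number in the series, and the step is a 1.4-fold higher number from compound 1 to compound 4 (0.16 log units; within the scatter), so replacing the 4-chlorophenyl with a group that counts a hydrogen-bond donor and acceptor does not separate the two compounds here. Amino in place of chloro on the same aromatic carbon gives an at least 1.0-fold lower number from compound 2 to compound 4 (0.02 log units; that floor lies within the scatter), and the comparison with the 3-bromophenyl gives an at least 1.0-fold lower number from compound 3 to compound 4 (0.02 log units; that floor lies within the scatter), so neither step shows a change beyond the scatter. Compound 2 and compound 3 still stand as limits and not as numbers: the limit of > 50000 nM in this assay, at which 2 of the 4 values shown sit.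

The step between compound 2 and compound 3 cannot be read, and no group shown on this nitrogen gives a step beyond the scatter, so it stays open whether this position can carry a clearly stronger or weaker compound at all. Compound 1 and compound 4 differ in both the substituent and its place on the phenyl, so a 4-aminophenyl on the same nitrogen would be needed to separate the two, and a carboxylic acid or a morpholine on that phenyl would test the position more widely.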